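A few compounds are considered here, and "the series" means these few. Any claim that something is new, unique, unknown or untested is made for them only; others in the source may bear on it.

Compound 1 `CN1CCC(C(=O)N2Cc3c(NC(=O)c4cc(F)cc(F)c4)n[nH]c3C2(C)C)CC1` stands at the ceiling of a physicochemical assay for solubility, at pH 7 (on this read-out higher numbers stand for higher solubility and lower numbers for lower solubility), where it reports > 225000 nM, a limit rather than a number. Compound 4 `CN1CCC(C(=O)N2Cc3c(NC(=O)c4ccccc4)n[nH]c3C2(C)C)CC1` is obtained from it by the change (phenyl in place of 3,5-difluorophenyl on a carbonyl carbon). For the measured compounds named here, no measured step touches the aryl ring. Going by the values given here, the single measured step, an at least 1.1-fold higher number from compound 2 to compound 3 (0.04 log units; that floor lies within the scatter), alters the amine nitrogen instead: compound 2 `CC(=O)N1CCC(C(=O)N2Cc3c(NC(=O)c4ccc(F)cc4)n[nH]c3C2(C)C)CC1` gives 204000 nM in this assay. Compound 3 `CCN1CCC(C(=O)N2Cc3c(NC(=O)c4ccc(F)cc4)n[nH]c3C2(C)C)CC1` reports > 225000 nM, which is a limit and not a number. As the limit of > 225000 nM in this assay, at which 2 of the 3 values shown sit, shows, most of the set already reaches the ceiling of this assay, so no step beyond the scatter is expected from compound 1 to compound 4. Compound 4 is therefore expected to give about 225000 nM, between 150000 nM and 260000 nM, the expected step being a number no higher from compound 1 to compound 4 (the limit leaves the size open).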

Compound 4, solubility: > 225000 nM
Compound 4 was reported as a limit; the forecaster's own chance of this, stated with the estimate: 55%; the middle value sits exactly at the limit.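

No step can be read from compound 1 to compound 4 in this assay, since both compounds report only a limit: the limit of > 225000 nM in this assay, at which 3 of the 4 values shown sit. The compounds shown leave open how phenyl and 3,5-difluorophenyl on a carbonyl carbon compare in this assay.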